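Methyl ester to free acid: tolerated concentration

The source may hold more compounds than are shown below. What is called first, only, known or untested is meant among the compounds shown, and "the series" means these compounds.

Measured compounds:
compound 1 `C=C1CC[C@@H]2C(C)(C)CCC[C@@]2(C)[C@@H]1CC/C(C)=C/C(=O)OC` — 69100 nM
compound 2 `C=C1CC[C@@H]2[C@](C)(CCC[C@]2(C)C(=O)O)[C@H]1CC/C(C)=C/C(=O)O` — 56800 nM

Two compounds of the series have been run in an ADME assay on LLC-MK2 cells (Macaca mulatta) for cytotoxicity, read by sulforhodamine B assay, with a stated time of 96 h; a lower number here means that less compound is tolerated, a higher number that more compound is tolerated. Compound 1 gives 69100 nM and carries the methoxycarbonyl group on its side chain. Compound 2, which gives 56800 nM, carries a carboxy group on the same side chain and a second carboxy group on the core. The two numbers lie within the scatter of each other, so compound 1 cannot be set apart from compound 2; both are tolerated at broadly the same concentration, and no change can be read between them.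

Compound 3 `C=C1CC[C@@H]2C(C)(C)CCC[C@@]2(C)[C@@H]1CC/C(C)=C/C(=O)O` is not yet measured. It differs from compound 1 in one place: hydrogen in place of methyl on an oxygen next to a carbonyl group. For the measured compounds named here, the only comparison at hand is that compound 2 already carries a carboxy group in that position and its number does not leave the scatter of compound 1. Compound 3 is therefore expected to give 60000 nM, with a range from 30000 nM to 120000 nM. The expected step is a 1.2-fold lower number from compound 1 to compound 3 (0.06 log units; within the scatter), nothing beyond the scatter in either direction.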

Compound 3, half-maximal cytotoxic concentration: 39400 nM
The estimate for compound 3 lay 1.5-fold (0.18 log units) above the measured number; low and high end bracket the measured number.
By their numbers in this assay, from the lowest: compounds 3, 2 and 1 (each within the scatter of the next).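

For the compounds shown here, compound 1 and compound 3 differ only in the side-chain ester, so this pair gives the first reading of the change on its own, without the second carboxy group on the core of compound 2. In this assay, methoxycarbonyl to carboxy on the 2-(methoxycarbonyl)-1-methylethenyl side chain gives a 1.8-fold lower number from compound 1 to compound 3 (0.24 log units; within the scatter), so hydrogen in place of methyl on an oxygen next to a carbonyl group does not set the two compounds apart. No measurement at hand accounts for this result or links it to any property of either group.

The compounds shown leave open how a primary amide, an ethyl ester or a longer ester chain at this position would read in this assay, and whether any of them would move the number beyond the scatter. Going by these compounds alone, they also leave open what the carboxy group on the core does on its own, as no pair here differs in that place alone.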